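Swapping an Acetoxy Group for a Silyl Group

The compounds below may be only part of what the source reports. "The series", "measured", "known", "first", "only" and "open" are said of these compounds alone.

Two related compounds have been tested in a functional assay on MCF7 cells (Homo sapiens) for antiproliferative activity, read by MTT assay, with a stated time of 48 h; on this read-out lower numbers stand for stronger inhibition and higher numbers for weaker inhibition. Compound 1 `CC(=O)OC/C1=C/C[C@](C)(CCC=C(C)C)/C=C/[C@@H](OC(=O)C=C(C)C)[C@](C)(O)/C=C/C1=O` gives 4510 nM in this assay, and compound 2 `C=C1/C=C/C(=O)/C(CO)=C\C[C@](C)(CCC=C(C)C)/C=C/[C@H]1OC(=O)C=C(C)C` gives 2750 nM. Compound 1 holds the higher of the two numbers, but the gap to compound 2 lies within the usual scatter of repeated measurements, so the two cannot be told apart on these data.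

The next compound, compound 3 `CC(C)=CCC[C@]1(C)/C=C/[C@@H](OC(=O)C=C(C)C)[C@](C)(O)/C=C/C(=O)/C(C[Si](C)(C)C(C)(C)C)=C\C1`, is not yet measured. It differs from compound 1 in one place: a group of 7 heavy atoms (6 carbon, 1 silicon; no ring) in place of a group of 4 heavy atoms (2 carbon, 2 oxygen; no ring), on a saturated chain carbon bound to a double-bonded ring carbon. The acetoxy group leaves, and a group of six carbon atoms and one silicon atom enters on the saturated chain carbon bound to a double-bonded ring carbon.

Going by the values given here, no measured pair shows what such a swap does in this assay, so the direction of the change is open. The step of a 1.2-fold lower number from compound 1 to compound 3 (0.07 log units; within the scatter) is expected to stay within the scatter, with no clear movement either way. Compound 3 is therefore estimated at 3800 nM, with a plausible range from 1200 nM to 12000 nM.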

Compound 3, half-maximal inhibitory concentration: 6040 nM
For compound 3 the middle estimate is 1.6-fold (0.20 log units) below the measured one, within the range that was stated.
By their numbers in this assay, from the lowest: compounds 2, 1 and 3 (each within the scatter of the next, the first and the last beyond it).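

In this assay, replacing the acetoxy group with the silicon-bearing group gives a 1.3-fold higher number from compound 1 to compound 3 (0.13 log units; within the scatter), the first step read at this place, on a saturated chain carbon bound to a double-bonded ring carbon. The two groups differ considerably on paper: the acetoxy group has 4 heavy atoms and 2 hydrogen-bond acceptors, while the group that enters has 7 heavy atoms, including silicon, and 0 hydrogen-bond acceptors, yet this assay cannot tell the two compounds apart, so on the shared core of compounds 1 and 3, the acetoxy group and its acceptors can be exchanged without a readable shift. Nothing measured here explains this outcome.

A single swap cannot separate the contribution of the silicon atom from that of the larger group, and it cannot show whether this place would tolerate other changes equally well. An amine, a carboxylic acid or a longer carbon chain at the same carbon could test whether the read-out stays as flat for groups of a different kind.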